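Difluoromethoxy in place of trifluoromethyl: what to expect

The source may report more compounds than this note shows. Statements on the series, on what has been measured and on what is new or still open speak of the compounds shown alone.

Going by the values given here, only two compounds with this shared core have been measured so far. In a functional assay on MCF-10A cells (Homo sapiens) for antiproliferative activity, with a stated time of 48 h (a higher number here means that more compound is needed for the effect, a lower number that less compound is needed), compound 1 `COc1ccc2nc(C)cc(NCc3ccccc3)c2c1` gives 25900 nM, while compound 2 `COc1ccc2nc(C)cc(NCc3ccc(C(F)(F)F)cc3)c2c1` gives 7600 nM, the lower of the two numbers. Less compound is therefore needed for the effect with compound 2.

The next compound, compound 3 `COc1ccc2nc(C)cc(NCc3ccc(OC(F)F)cc3)c2c1`, differs from compound 2 in one place: difluoromethoxy in place of trifluoromethyl on an aromatic carbon. In short, it has difluoromethoxy in place of trifluoromethyl on an aromatic carbon, para to a large group.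

Among the compounds with values here, one measured step bears on this change, and only indirectly: a 3.4-fold lower number from compound 1 to compound 2 (0.53 log units; beyond the scatter), seen with trifluoromethyl in place of hydrogen on an aromatic carbon. Within the data shown here, no measurement yet tests difluoromethoxy itself. Compound 3 still carries a fluorine-bearing group at that place, so most of the gain seen in a 3.4-fold lower number from compound 1 to compound 2 (0.53 log units; beyond the scatter) is expected to remain, with perhaps a slight drift back towards compound 1. The expected change is a 1.3-fold higher number from compound 2 to compound 3 (0.12 log units; within the scatter), and no step beyond the scatter is anticipated. In this assay, the estimate for compound 3 is 10000 nM, with a range of 4500 nM to 21000 nM.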

Compound 3, half-maximal effective concentration: 10400 nM
For compound 3 the middle estimate is 1.0-fold (0.02 log units) below the measured one, within the range that was stated.
By their numbers in this assay, from the lowest: compounds 2 and 3 (each within the scatter of the next); then compound 1.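

In this assay, the step of a 1.4-fold higher number from compound 2 to compound 3 (0.14 log units; within the scatter) shows that trifluoromethyl and difluoromethoxy cannot be told apart at this place on the aromatic ring, even though difluoromethoxy brings an oxygen and a hydrogen-bond acceptor that trifluoromethyl lacks. The step of a 2.5-fold lower number from compound 1 to compound 3 (0.40 log units; beyond the scatter) shows that the drop in the number seen with trifluoromethyl is not unique to that group, since a second fluorine-bearing group, para to a large group, also gives a number clearly lower than hydrogen does. No measured property is available to explain why either group has this effect.

Going by these compounds, both groups that lower the number contain fluorine, so it remains open whether fluorine matters here or whether a group without it, such as methoxy, an amine or a carboxylic acid, would give a similar number. On these data alone, it is also open how much room this place allows, which a longer chain carrying fluorine at its end could begin to test.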